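Moving the chlorine around the ring of compound 3

This account rests on a few compounds, and the source may have more. Where it says the series, first, only, none or still open, it means among the compounds named here.

Compound 3 `COc1cccc(OS(=O)(=O)/C=C/c2cccc(Cl)c2)c1` is measured in an assay on U2OS cells for activation of nuclear factor erythroid 2-related factor 2 (Homo sapiens), read by chemiluminescence, with a stated time of 6 h (on this read-out higher numbers stand for an effect only at larger amounts of compound and lower numbers for an effect already at smaller amounts), at 943 nM, the highest of the two numbers shown. Compound 2 `COc1cccc(OS(=O)(=O)/C=C/c2ccccc2Cl)c1` gives 165 nM in this assay. Compound 1 `O=S(=O)(/C=C/c1ccccc1Cl)Nc1ccccc1` reaches only a limit in this assay, > 10000 nM. Among the measured compounds shown here, the one measured step that bears on where the chlorine sits, a 5.7-fold higher number from compound 2 to compound 3 (0.76 log units; beyond the scatter), went toward a higher number. Compound 4 `COc1cccc(OS(=O)(=O)/C=C/c2ccc(Cl)cc2)c1` differs from compound 3 by 4-chlorophenyl in place of 3-chlorophenyl on a double-bonded chain carbon bound to a double-bonded chain carbon. For the measured compounds named here, with only that single step as a guide, the change is expected to give a step of a 1.6-fold higher number from compound 3 to compound 4 (0.20 log units; within the scatter) in this assay, a small move toward a higher number or none beyond the scatter. Compound 4 is therefore estimated at 1500 nM, with a range from 400 nM to 6000 nM.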

Compound 4, half-maximal effective concentration: 1780 nM
The estimate for compound 4 lay 1.2-fold (0.07 log units) below the measured number; the range from low to high includes it.
By their numbers in this assay, from the lowest: compound 2; then compounds 3 and 4 (each within the scatter of the next). At a limit, above all of these: compound 1.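

The change to 4-chlorophenyl gives a 1.9-fold higher number from compound 3 to compound 4 (0.28 log units; within the scatter), so 3-chlorophenyl and 4-chlorophenyl cannot be told apart on this read-out. Only 2-chlorophenyl stands apart, with an 11-fold higher number from compound 2 to compound 4 (1.03 log units; beyond the scatter), and the lower number now holds against both other chlorine placements among these compounds. Nothing shown here accounts for this difference between the chlorine placements. As far as these compounds go, what remains open is whether a fluorine or a nitrile in place of the chlorine of compound 2 would keep its number.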